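This account rests on a few compounds, and the source may have more. Where it says the series, first, only, none or still open, it means among the compounds named here.

In a functional assay on HL-60 cells (Homo sapiens) for antiproliferative activity, with a stated time of 72 h (on this read-out higher numbers stand for weaker inhibition of growth and lower numbers for stronger inhibition of growth), compound 1 `C=C(CC)C(=O)c1ccc(OCC(=O)O)cc1Cl` gives > 60000 nM, which is a limit of the assay rather than a number. Compound 3 `C=C(CC)C(=O)c1ccc(OC(C)C(=O)O)cc1Cl` carries methyl in place of hydrogen on a saturated chain carbon bound to a carbonyl carbon and an oxygen on an aromatic ring and in this assay gives > 60000 nM, again only a limit. The step that the two limits leave unreadable from compound 1 to compound 3 thus cannot be sized, since the limit of > 60000 nM in this assay, at which 2 of the 3 values shown sit, holds both of its ends. Going by the values given here, compound 2 `C=C(C)C(=O)c1ccc(OC(C)C(=O)OC)c(C)c1C` has a core whose difference from the core of compound 1 is not broken down here; in this assay compound 2 gives 6000 nM, the one number among the three measured. Compound 4 `C=C(CC)C(=O)c1ccc(OC(C)C(=O)OC)c(C)c1C` is still to be measured. It carries methyl in place of hydrogen on a saturated chain carbon bound to a double-bonded chain carbon, the same kind of change as that from compound 1 to compound 3, though here on a saturated chain carbon bound to a double-bonded chain carbon rather than on a saturated chain carbon bound to a carbonyl carbon and an oxygen on an aromatic ring. Set beside that unreadable earlier step, a 1.2-fold higher number from compound 2 to compound 4 (0.07 log units; within the scatter) is the expected size, resting on compound 2 at 6000 nM as the only number available. In this assay compound 4 is therefore estimated at 7000 nM, between 2500 nM and 25000 nM.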

Compound 4, concentration for 50% growth inhibition: 4600 nM
The estimate for compound 4 lay 1.5-fold (0.18 log units) above the measured number; low and high end bracket the measured number.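

In this assay the new step is a 1.3-fold lower number from compound 2 to compound 4 (0.12 log units; within the scatter), so on this core, methyl in place of hydrogen on a saturated chain carbon bound to a double-bonded chain carbon, which reads as methyl to ethyl, gives no difference that can be told from the scatter. This is one pair on one core, and the compounds shown hold no matching methyl-to-ethyl pair on the core of compound 1, so it does not show whether the result carries over to another core. The one other methyl step, from compound 1 to compound 3, lies at a different place and cannot be read, since both of its ends are limits: the limit of > 60000 nM in this assay, at which 2 of the 4 values shown sit.

From the compounds shown here alone, it remains open whether a longer chain, such as propyl, at this place would also stay within the scatter of compound 2. Also open, going by these compounds, is how an amine in place of the methyl ester on the core of compound 2 would read in this assay.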